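This account rests on a few compounds, and the source may have more. Where it says the series, first, only, none or still open, it means among the compounds named here.

For the measured compounds named here, compound 1 `C[C@H](NCc1ccc(OCCCCCN2CCN(c3cccc4c3ccn4Cc3cccc(Cl)c3)CC2)cc1)C(N)=O` is the higher of the two compounds measured so far. In an assay on BTI cells for inhibition of Amine oxidase [flavin-containing] B (Homo sapiens), read by fluorescence, with stated times of 30 min and 1 h, tested at 1 uM (a higher number here means more inhibition at the concentration tested (going by the name of the read-out), a lower number less inhibition), compound 1 gives 43%, while compound 2 `C[C@H](NCc1ccc(OCCCCCN2CCN(c3cccc4c3ccn4S(=O)(=O)c3ccccc3)CC2)cc1)C(N)=O`, which carries phenylsulfonyl in place of 3-chlorobenzyl on an aromatic nitrogen, gives 17% in this assay. That change reads as a number 26 percentage points lower from compound 1 to compound 2 (beyond the scatter), a step beyond the scatter but at the opposite end of the shared core from the change now in question.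

Compound 3 `C#CCN(C)Cc1ccc(OCCCCCN2CCN(c3cccc4c3ccn4Cc3cccc(Cl)c3)CC2)cc1` differs from compound 1 by methyl(propargyl)amino in place of (1-carbamoylethyl)amino on a saturated chain carbon bound to an aromatic carbon. Going by the values given here, the only measured step concerns the group on the aromatic nitrogen, not the saturated chain carbon bound to an aromatic carbon, so no measured step bears directly on this change, and neither its direction nor its size can be read from the two numbers in hand. The expectation therefore rests on compound 1 alone, with a wide range in either direction. Compound 3 is expected to give 65% in this assay, within 25% to 95%, which would mean an estimated step of a number 22 percentage points higher from compound 1 to compound 3 (beyond the scatter).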

Compound 3, a percentage reported as inhibition, at one concentration (the size of the read-out at that concentration, not a potency): 100%
Estimate against measurement, compound 3: 35 percentage points below; measured number above the stated range.
By their numbers in this assay, from the lowest: compound 2; then compound 1; then compound 3.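

In this assay, the group on the saturated chain carbon bound to an aromatic carbon has a strong influence on the read-out: there is a number 57 percentage points higher from compound 1 to compound 3 (beyond the scatter), a wider step than a number 26 percentage points lower from compound 1 to compound 2 (beyond the scatter), which was made on the aromatic nitrogen. The change replaces the carbamoyl group, the defined stereocentre and all hydrogen-bond donors of (1-carbamoylethyl)amino while bringing in a triple bond, so this single step cannot assign the gain to any one of these features. Nothing available here accounts for the size of the step.

A saturated counterpart such as methyl(propyl)amino, or a smaller dimethylamino group, would separate the part played by the propargyl triple bond from that of simply losing the carbamoyl side chain. Also open, as far as these compounds go, is whether phenylsulfonyl on the aromatic nitrogen would lower the number as much alongside methyl(propargyl)amino, and how compound 3 ranks in potency, since a percentage at one concentration, here 100%, is not a potency.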